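The compounds below may be only part of what the source reports. "The series", "measured", "known", "first", "only" and "open" are said of these compounds alone.

Compound 1 `CN1CCN(c2ccc(S(=O)(=O)Oc3cccc(F)c3)cc2)C1=O` and compound 2 `CN1CCN(c2ccc(S(=O)(=O)Oc3cccc(Cl)c3)cc2)C1=O` share one core and differ in a single place: chloro in place of fluoro on an aromatic carbon. In a functional assay on MCF7 cells (Homo sapiens) for antiproliferative activity, read by sulforhodamine B assay, with a stated time of 48 h (on this read-out higher numbers stand for weaker inhibition and lower numbers for stronger inhibition), compound 1 gives only a limit, > 100000 nM, which is the limit of > 100000 nM in this assay, at which 1 of the 3 values shown sits. In this assay compound 2 gives 2200 nM. The step between them is an at least 45-fold lower number from compound 1 to compound 2 (1.65 log units; beyond the scatter), and because compound 1 sits at the limit of > 100000 nM in this assay, at which 1 of the 3 values shown sits, the true size of that step is not known, only its floor. Compound 3 `CCCN1CCN(c2ccc(S(=O)(=O)Oc3ccc(F)cc3)cc2)C1=O` has a different core; the difference between the two cores is not broken down here. In this assay compound 3 gives 33000 nM. Compound 4 `CCCN1CCN(c2ccc(S(=O)(=O)Oc3ccc(Cl)cc3)cc2)C1=O` has not yet been measured. It differs from compound 3 by chloro in place of fluoro on an aromatic carbon, the same kind of change as from compound 1 to compound 2, though the place now reads para to a large group where before it read meta to a large group. With the earlier step known only as a floor, a smaller step is expected here, an 11-fold lower number from compound 3 to compound 4 (1.04 log units; beyond the scatter). Compound 4 is estimated at 3000 nM, expected between 800 nM and 15000 nM.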

Compound 4, half-maximal inhibitory concentration: 18000 nM
Compound 4: the middle estimate sits 6.0-fold (0.78 log units) below what was measured; measured number above the stated range.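

On the core of compound 3, the swap of fluoro for chloro gives a 1.8-fold lower number from compound 3 to compound 4 (0.26 log units; within the scatter), so the large drop seen on the other core does not carry over at that size in this assay, and the two steps differ: the same change on two cores in this assay, an at least 45-fold lower number (1.65 log units; beyond the scatter) from compound 1 to compound 2 and a 1.8-fold lower number (0.26 log units; within the scatter) from compound 3 to compound 4, at least 24-fold (1.39 log units) apart, beyond the scatter of two such steps. This does not show what makes them differ, since the two pairs differ both in their core and in where the halogen sits on the ring, and these two differences cannot be separated with the compounds shown. On these data alone, compound 1 gives only a limit, so the earlier step is known only as a floor and its full size stays unknown: the limit of > 100000 nM in this assay, at which 1 of the 4 values shown sits.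

Still open, as far as these compounds go, is whether the same swap would give a larger step on the core of compound 3 with the halogen placed as it is in compound 2. Also open, from the compounds shown here alone, is how a bromo or a methoxy group would compare with chloro at the place held in compound 4.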